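The source may hold more compounds than are shown below. What is called first, only, known or untested is meant among the compounds shown, and "the series" means these compounds.

Compound 1 `Cc1c(OCCCCOc2ccc(C(=O)O)cc2)ccc(C(=O)CC2CCCC2)c1O` has been tested in an assay on HEK293 cells for positive allosteric modulation of metabotropic glutamate receptor 3 (Rattus norvegicus), read by thallium flux, with a stated time of 2.5 min; a lower number here means that less compound is needed, a higher number that more compound is needed for the effect. In this assay compound 1 gives > 10000 nM, which is a limit of the assay and not a number. Compound 1 thus sits at the limit described in the limit of > 10000 nM in this assay, at which 1 of the 2 values shown sits, one of the two entries shown. Compound 2 `Cc1c(OCCCCOc2ccccc2C(=O)O)ccc(C(=O)CC2CCCC2)c1C` has no result in this assay, its entry reading "not determined" (no result reported). Compound 3 `Cc1c(OCCCCOc2ccc(C(=O)O)cc2F)ccc(C(=O)CC2CCCC2)c1O` has not yet been measured. It differs from compound 1 in one place: fluoro in place of hydrogen on an aromatic carbon. Within the data shown here, no step between two measured compounds is known, so no measured change guides the expectation. With compound 1 resting at a limit, the step is expected to be a step that the limit leaves unreadable from compound 1 to compound 3, in no direction beyond the usual scatter. Compound 3 is therefore estimated at 12000 nM, with a range from 4000 nM to 40000 nM, and a strong chance that only a limit is reported again.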

Compound 3, half-maximal effective concentration: > 10000 nM
Compound 3: no number, only a limit (the forecaster's own chance of this, stated with the estimate: 70%); the middle value is on the limit's open side.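

In this assay compound 1 and compound 3 both stop at a limit and give no number, so no step between them can be read: the limit of > 10000 nM in this assay, at which 2 of the 3 values shown sit.

The compounds shown leave open whether fluoro in place of hydrogen changes the half-maximal effective concentration at all, and which change to the shared core would yield a measurable value.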